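The source may report more compounds than this note shows. Statements on the series, on what has been measured and on what is new or still open speak of the compounds shown alone.

In a physicochemical assay for lipophilicity, measured as octanol-water partition, at pH 7.4 (a lower number here means a more polar compound, a higher number a more lipophilic compound), three related compounds have been measured so far. Compound 1 (`Cc1ccc2[nH]c(C(=O)N[C@H]3CN(S(=O)(=O)c4ccccc4)CC[C@@H]3C(=O)NCCN(C)C)cc2c1`) gives 1.9. Compound 2 (`Cc1ccc2[nH]c(C(=O)N[C@H]3CCN(S(=O)(=O)c4ccccc4Cl)C[C@@H]3C(=O)N[C@H]3CCCN(C)C3)cc2c1`) gives 3.1. Compound 3 (`O=C(N[C@H]1CN(S(=O)(=O)c2ccccc2)C[C@@H]1C(=O)N[C@H]1CCCNC1)c1cc(C2CC2)n[nH]1`) gives 0.2, the lowest of the three numbers, and its gaps to both of the others lie beyond the usual scatter of repeated measurements.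

Compound 4 (`O=C(N[C@H]1CN(S(=O)(=O)c2ccccc2)C[C@@H]1C(=O)N[C@H]1CCCNC1)c1cc(-c2ccccc2)on1`) has not yet been measured. It has 5-phenyl-1,2-oxazol-3-yl in place of 3-cyclopropyl-1H-pyrazol-5-yl on a carbonyl carbon. In this swap, a six-membered aromatic ring of carbon only enters and a three-membered non-aromatic ring of carbon only leaves, while each group keeps a five-membered aromatic ring with 2 hetero atoms.

Among the compounds with values here, no two measured compounds differ in only one place, so no measured step can serve as a guide. The expectation rests on the structural change alone, starting from compound 3 at 0.2. The larger group that enters, which carries no hydrogen-bond donor, points to an upward move in this assay, beyond the scatter. The expected change is a number 1.10 log units higher from compound 3 to compound 4 (beyond the scatter). For compound 4 the estimated value is 1.3, with an expected range from 0.7 to 1.9.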

Compound 4, distribution coefficient: 1.3
Compound 4: middle estimate and measured number agree at the digits printed; low and high end bracket the measured number.
By their numbers in this assay, from the lowest: compound 3; then compound 4; then compound 1; then compound 2.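

Within the data shown here, this is the first pair that differs in only one place, so this assay can now be read for a single change: on a carbonyl carbon whose other neighbour is an amide-type nitrogen, 5-phenyl-1,2-oxazol-3-yl in place of 3-cyclopropyl-1H-pyrazol-5-yl gives a number 1.10 log units higher from compound 3 to compound 4 (beyond the scatter). The read-out therefore does respond to the group at this place, but the swap alters several things at once: a six-membered aromatic ring of carbon only replaces a three-membered ring of carbon only, the five-membered ring changes its hetero atoms, and the hydrogen-bond donor count of the group goes from 1 to 0. No measured evidence here singles out which of these differences accounts for the step.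

The compounds shown leave open how the step divides between the phenyl ring and the five-membered ring that carries it, and a 5-cyclopropyl-1,2-oxazol-3-yl group on the same carbonyl carbon would help to separate the two. Among these compounds, compounds 1 and 2 differ from these two in more than one place, so no steps to them can be read, and whether this change behaves alike on their cores stays open.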